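The compounds below may be only part of what the source reports. "The series", "measured", "known", "first", "only" and "open" are said of these compounds alone.

Measured so far:
compound 1, `Fc1cccc(F)c1-c1nc2cccnc2o1`: 50%
compound 2, `CSc1ccccc1-c1nc2ncccc2o1`: 21%

Two compounds of the series have been run in a functional assay on the whole organism for inhibition, with Rattus norvegicus as the target, at a dose of 30 mg/kg; on this read-out higher numbers stand for more inhibition at the one dose given (going by the name of the read-out) and lower numbers for less inhibition. Compound 1 gives 50%. Compound 2 gives 21%, the lowest of the two numbers; the nearest value, that of compound 1, sits higher by a margin beyond the scatter. Within the data shown here, no single-change step links compound 1 and compound 2, so their two values show only that compound 2 stands lower.

Compound 3, `Clc1ccccc1-c1nc2ncccc2o1`, remains to be measured. Its relation to compound 2 is chloro in place of methylsulfanyl on an aromatic carbon. Among the measured compounds shown here, no step of this kind has been measured, so there is no reference for how chloro in place of methylsulfanyl moves this assay. Working expectation: a modest rise from compound 2, at or just beyond the scatter, rather than a large move in either direction. Compound 3 is estimated at 30%, with a range from 5% to 60%. This estimate implies a step of a number 9 percentage points higher from compound 2 to compound 3 (within the scatter), expected to sit close to the edge of the scatter.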

Compound 3, a percentage reported as inhibition, in the whole organism at one dose (the size of the read-out at that dose, not a potency): 38%
The estimate for compound 3 lay 8 percentage points below the measured number; the measured number falls inside the stated range.
By their numbers in this assay, from the lowest: compound 2; then compound 3; then compound 1.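

In this assay, among these compounds, chloro in place of methylsulfanyl on an aromatic carbon of a six-membered aromatic ring of carbon only, ortho to a group of 9 heavy atoms, gives a number 17 percentage points higher from compound 2 to compound 3 (beyond the scatter) and is the first single-change comparison. The read-out therefore responds to the group held at this position, with the step going up when chloro replaces methylsulfanyl, a direction that the earlier pair could not show. This single swap changes the sulfur, the carbon attached to it and the hydrogen-bond acceptor count together, and no measurement at hand bears on what lies behind the step.

Going by these compounds, whether the trend extends beyond these two groups stays open: an unsubstituted carbon at this position would provide a baseline, while methoxy, an amine or a carboxylic acid there would show how far the read-out follows other kinds of group. Compound 1 differs from compound 3 in more than one place, so the contribution of each of those differences remains unassigned.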